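From quinolin-6-yl to naphthalen-1-yl on a shared core

The source may report more compounds than this note shows. Statements on the series, on what has been measured and on what is new or still open speak of the compounds shown alone.

In a functional assay on MDA-MB-231 cells (Homo sapiens) for antiproliferative activity, with a stated time of 5 days (a lower number here means a stronger inhibitor, a higher number a weaker inhibitor), compound 1 (`O=C1C=CC2(C=C1)OCC(=O)N2c1nc(-c2ccc3ncccc3c2)nn1-c1ccccc1`) gives 50 nM as its half-maximal inhibitory concentration. In this assay compound 2 (`COc1ccc(-n2nc(-c3ccc4ccccc4c3)nc2N2C(=O)C(C)OC23C=CC(=O)C=C3)cc1`) gives 50 nM and compound 3 (`O=C1C=CC2(C=C1)OCC(=O)N2c1nc(-c2ccc3ccccc3c2)nn1-c1ccc2ccccc2c1`) gives 50 nM as well, so compound 1 stands level with both and the three cannot be ranked.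

Compound 4 (`O=C1C=CC2(C=C1)OCC(=O)N2c1nc(-c2cccc3ccccc23)nn1-c1ccccc1`) has not yet been measured. It differs from compound 1 in one place, on an aromatic carbon of a five-membered aromatic ring with 3 nitrogen, between two ring nitrogen atoms: naphthalen-1-yl in place of quinolin-6-yl (naphthalen-1-yl in place of quinolin-6-yl on an aromatic carbon).

Among the measured compounds shown here, no measured pair isolates this change, so the evidence is indirect. Compound 2 at 50 nM and compound 3 at 50 nM both carry two six-membered aromatic rings of carbon only at that place, which suggests that a ring nitrogen there is not essential. For the measured compounds named here, both also differ from compound 1 elsewhere, however, and no measured compound carries naphthalen-1-yl itself. With that group untested, a modest weakening seems more likely than a large one, and the expected change is a 2.0-fold higher number from compound 1 to compound 4 (0.30 log units; within the scatter) in size. Compound 4 is estimated at 100 nM within a range of 30 nM to 400 nM on this reckoning.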

Compound 4, half-maximal inhibitory concentration: 50 nM
Compound 4: the middle estimate sits 2.0-fold (0.30 log units) above what was measured; measured number inside the range.
By their numbers in this assay, from the lowest: compounds 1, 2, 3 and 4 (each within the scatter of the next).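

In this assay, among the compounds shown here, replacing quinolin-6-yl with naphthalen-1-yl gives no change at the digits printed from compound 1 to compound 4 (within the scatter), the first direct reading of a change at this place, on the aromatic carbon of the five-membered aromatic ring with 3 nitrogen. Compounds 2 and 3 could only hint at this, and they also differ from compound 1 elsewhere. This single change shows that, on the shared core with its phenyl group, the ring nitrogen and the hydrogen-bond acceptor counted in quinolin-6-yl can be absent with no change beyond the scatter, even though the two groups are also joined to the core through different ring positions, as their names show. Nothing measured here explains this result.

Still open, from the compounds shown here alone, is how far this place accepts groups of a different kind, since both groups compared here are fused pairs of six-membered aromatic rings, and an amine, a carboxylic acid or a longer alkyl chain on the same carbon might read quite differently. Going by these compounds, it is also open whether the same swap would give the same reading if a pyridine ring stood in place of the phenyl group on the core.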